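The source may report more compounds than this note shows. Statements on the series, on what has been measured and on what is new or still open speak of the compounds shown alone.

Measured compounds:
compound 1 `COC1CCN(CC(=O)N2CCN(c3sc(C(F)(F)F)nc3-c3nc4ccccc4[nH]3)C[C@H]2C)C1` gives 3380 nM
compound 2 `Cc1nn(CC(=O)N2CCN(c3sc(C(F)(F)F)nc3-c3nc4ccccc4[nH]3)C[C@H]2C)cc1CN(C)C` gives 330 nM
compound 3 `Cc1nc(C)n(CC(=O)N2CCN(c3sc(C(F)(F)F)nc3-c3nc4ccccc4[nH]3)C[C@H]2C)n1` gives 237 nM

All three numbers come from a functional assay on Venous blood for antagonist activity at C-X-C chemokine receptor type 3 (Homo sapiens), read by flow cytometry, with a stated time of 30 min, in the presence of a further agent that is not named here; on this read-out lower numbers stand for stronger inhibition and higher numbers for weaker inhibition. Compound 2 holds the second highest of the three numbers. Its nearest neighbour is compound 3, with a 1.4-fold lower number from compound 2 to compound 3 (0.14 log units; within the scatter); the furthest is compound 1, with a 10-fold lower number from compound 1 to compound 2 (1.01 log units; beyond the scatter).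

The next compound in the series is compound 4 `C[C@@H]1CN(c2sc(C(F)(F)F)nc2-c2nc3ccccc3[nH]2)CCN1C(=O)Cn1cnc2cccnc21`. Against compound 2 the change is a group of 9 heavy atoms (6 carbon, 3 nitrogen; one five-membered aromatic ring with 2 hetero atoms, one six-membered aromatic ring with 1 hetero atom) in place of a group of 10 heavy atoms (7 carbon, 3 nitrogen; one five-membered aromatic ring with 2 hetero atoms), on a saturated chain carbon bound to a carbonyl carbon. The measured steps that bear on it are the two that exchange the group at this same place. Replacing the saturated ring of compound 1 with an aromatic five-membered ring gave large steps, a 10-fold lower number from compound 1 to compound 2 (1.01 log units; beyond the scatter) and a 14-fold lower number from compound 1 to compound 3 (1.15 log units; beyond the scatter), whereas exchanging one aromatic five-membered ring for another gave only a 1.4-fold lower number from compound 2 to compound 3 (0.14 log units; within the scatter). Compound 4 again carries an aromatic ring at this place, so the step is expected to resemble that between compound 2 and compound 3 rather than those from compound 1: no change beyond the scatter, estimated as a 1.1-fold lower number from compound 2 to compound 4 (0.04 log units; within the scatter) in this assay. Compound 4 is therefore expected to give about 300 nM in this assay, with a likely range from 120 nM to 800 nM.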

Compound 4, half-maximal inhibitory concentration in the C-X-C chemokine receptor type 3 assay: 70 nM
Estimate against measurement, compound 4: 4.3-fold (0.63 log units) above; the measured number lies below the stated range.
By their numbers in the C-X-C chemokine receptor type 3 assay, from the lowest: compound 4; then compounds 3 and 2 (each within the scatter of the next); then compound 1.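

In the C-X-C chemokine receptor type 3 assay, aromatic groups at this place are no longer interchangeable: the group with one five-membered and one six-membered aromatic ring gives a 4.7-fold lower number from compound 2 to compound 4 (0.67 log units; beyond the scatter) and a 3.4-fold lower number from compound 3 to compound 4 (0.53 log units; beyond the scatter), whereas the exchange of one aromatic five-membered ring for another stayed within the scatter. This widens the span seen on the saturated chain carbon bound to a carbonyl carbon, with a 48-fold lower number from compound 1 to compound 4 (1.68 log units; beyond the scatter) now the largest step in the set. The lower number also comes with a clear rise in lipophilicity, which compounds 1 to 3 alone could not show, as read in a physicochemical assay for lipophilicity, at pH 7.4; a lower number here means a more polar compound, a higher number a more lipophilic compound: the measured distribution coefficient of compound 2, 2.4, and of compound 4, 3.9, a number 1.50 log units higher (beyond the scatter) In the physicochemical assay compound 2 gives 2.4 and compound 4 gives 3.9.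

The compounds shown do not separate the added six-membered aromatic ring from the rise in lipophilicity as the source of the lower number in the C-X-C chemokine receptor type 3 assay. An amine or a carboxylic acid on the six-membered aromatic ring of compound 4 would show whether that number holds when the ring stays and the distribution coefficient falls.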